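The source may hold more compounds than are shown below. What is called first, only, known or untested is meant among the compounds shown, and "the series" means these compounds.

In a functional assay on CHO cells for agonist activity at Free fatty acid receptor 2 (Homo sapiens), read by cAMP accumulation (a higher number here means a weaker inhibitor, a lower number a stronger inhibitor), compound 3 `CC(C)[C@H](C(=O)Nc1ccccn1)c1ccc(Cl)cc1` stands lowest of the two numbers shown, giving 1400 nM. Its nearest neighbour, compound 2 `CNC(=O)[C@H](c1ccc(Cl)cc1)C(C)C`, gives 11000 nM in this assay. For compound 1 `CC(C)C(C(N)=O)c1ccc(Cl)cc1` this assay reports only a limit, > 100000 nM, which is the limit of > 100000 nM in this assay, at which 1 of the 3 values shown sits, and not a number.

Among the compounds with values here, only one step between measured compounds changes a single place: a 7.9-fold lower number from compound 2 to compound 3 (0.90 log units; beyond the scatter). Compound 4 `CC(C)[C@H](C(=O)Nc1ncc[nH]1)c1ccc(Cl)cc1` differs from compound 3 by 1H-imidazol-2-yl in place of pyridin-2-yl on an amide-type nitrogen. Within the data shown here, no measured step exchanges one aromatic ring on the amide-type nitrogen for another, so the bearing of the earlier step is indirect: it shows that an aromatic ring in place of methyl on that nitrogen lowered the number, and compound 4 keeps an aromatic ring there. Compound 4 is therefore expected to give about 2000 nM in this assay, between 500 nM and 8000 nM. The expected step, a 1.4-fold higher number from compound 3 to compound 4 (0.15 log units; within the scatter), is estimated to lie within the scatter, in no clear direction.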

Compound 4, half-maximal inhibitory concentration: 20000 nM
The estimate for compound 4 lay 10-fold (1.00 log units) below the measured number; measured number above the stated range.
By their numbers in this assay, from the lowest: compound 3; then compounds 2 and 4 (each within the scatter of the next). At a limit, above all of these: compound 1.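

The amide-type nitrogen proves sensitive to which aromatic ring it carries: in this assay putting 1H-imidazol-2-yl in place of pyridin-2-yl gives a 14-fold higher number from compound 3 to compound 4 (1.15 log units; beyond the scatter) and the lower number seen with pyridin-2-yl therefore does not extend to every aromatic ring at this place. Against methyl, 1H-imidazol-2-yl offers no change beyond the scatter, with a 1.8-fold higher number from compound 2 to compound 4 (0.26 log units; within the scatter) and so an aromatic ring on this nitrogen is not enough in itself to lower the number. Nothing measured here bears on why the two rings differ.

The five-membered ring and the added hydrogen-bond donor enter together, and the compounds shown do not separate them. Also open, from the compounds shown here alone, is how a phenyl or a thiazolyl ring on this nitrogen would read.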